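The source may report more compounds than this note shows. Statements on the series, on what has been measured and on what is new or still open speak of the compounds shown alone.

Compound 1 `CC1=CC[C@@H]([C@@](C)(O)CCCC(C)(C)NC=S)CC1`, compound 2 `CC1=CC[C@@H]([C@@](C)(O)CCCC(C)(C)NC(=S)NN)CC1` and compound 3 `CC1=CC[C@@H]([C@@](C)(O)CCCC(C)(C)NC(=S)N/N=C\c2ccccc2)CC1` share one core and differ only at the thiocarbonyl end. In a functional assay on UACC-62 cells (Homo sapiens) for cytotoxicity, read by sulforhodamine B assay (a higher number here means a weaker inhibitor of growth, a lower number a stronger inhibitor of growth), compound 1 gives 9960 nM, compound 2 gives 18500 nM, and compound 3 gives 12700 nM. Among these three numbers compound 3 sits second highest, with compound 1 nearest and compound 2 furthest, and every gap among them stays within the scatter: a 1.9-fold higher number from compound 1 to compound 2 (0.27 log units; within the scatter), a 1.3-fold higher number from compound 1 to compound 3 (0.11 log units; within the scatter) and a 1.5-fold lower number from compound 2 to compound 3 (0.16 log units; within the scatter).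

Compound 4 `CC1=CC[C@@H]([C@@](C)(O)CCCC(C)(C)NC(=S)N/N=C\c2ccc(C)cc2)CC1` is built from compound 3 by a single change, (methyl in place of hydrogen on an aromatic carbon). Among the measured compounds shown here, no measured step touches the aromatic ring itself, so none bears on this change directly. What the three steps do show is that far larger changes at the same end of the molecule, including adding the whole aromatic group, moved this assay by no more than the scatter. A change as small as one methyl is therefore expected to give no step beyond the scatter, a 1.1-fold lower number from compound 3 to compound 4 (0.02 log units; within the scatter). Compound 4 is estimated at 12000 nM, within a range from 6000 nM to 25000 nM.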

Compound 4, concentration for 50% growth inhibition: 11600 nM
Compound 4: the middle estimate sits 1.0-fold (0.01 log units) above what was measured, within the range that was stated.
By their numbers in this assay, from the lowest: compounds 1, 4, 3 and 2 (each within the scatter of the next).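

Among the compounds shown here, compound 4 gives the first reading on the aromatic ring itself, which no earlier step touched. In this assay, methyl on an aromatic carbon, para to a large group, gives a 1.1-fold lower number from compound 3 to compound 4 (0.04 log units; within the scatter) and so cannot be told apart from hydrogen at this position, while the much larger swap of the end nitrogen for the group carrying the 4-methylphenyl gives a 1.6-fold lower number from compound 2 to compound 4 (0.20 log units; within the scatter) and stays just as unresolved. Nothing available accounts for how close these numbers lie.

On these data alone, one methyl is a small probe, so it remains open whether an amine, a carboxylic acid or a longer chain on the same ring carbon would move the number beyond the scatter. As far as these compounds go, it also remains open whether methyl on another carbon of that ring would read the same.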